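The source may report more compounds than this note shows. Statements on the series, on what has been measured and on what is new or still open speak of the compounds shown alone.

Compound 1 `COc1ccc(-c2cnccn2)c2cc(C(=O)Nc3ccc(Cn4ccnc4)cc3)oc12`: "not determined" (no result reported)
Compound 2 `COc1ccc(-c2cccnc2)c2cc(C(=O)Nc3ccc(Cn4ccnc4)cc3)oc12`: 60%

Two compounds share one core here. For the measured compounds named here, in a functional assay on the whole organism for inhibition, with Mus musculus as the target, at a dose of 10 mg/kg by the oral route (on this read-out lower numbers stand for less inhibition and higher numbers for more inhibition at the one dose given (going by the name of the read-out)), compound 2 gives 60%, the only number in the set. For compound 1 the same read-out stands as "not determined" (no result reported), so compound 2 cannot be placed against anything; it is simply the one measured point. Compound 3 `COc1ccc(-c2ccncc2)c2cc(C(=O)Nc3ccc(Cn4ccnc4)cc3)oc12` is the untested partner of compound 2. The change between them is pyridin-4-yl in place of pyridin-3-yl on an aromatic carbon. Going by the values given here, no step between two measured compounds is known, so there is no measured guide to how much a shift of the nitrogen within the pyridinyl may matter. The expectation is a change no larger than the scatter, in either direction, with a slight lean downward. The step from compound 2 to compound 3 is estimated as a number 5 percentage points lower from compound 2 to compound 3 (within the scatter). Compound 3 is expected to give about 55% in this assay, within 30% to 80%.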

Compound 3, a percentage reported as inhibition, in the whole organism at one dose (the size of the read-out at that dose, not a potency): 60%
Compound 3: the middle estimate sits 5 percentage points below what was measured, and the stated range covers the measured number.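

In this assay, for the compounds shown here, the only measured step at this position reads no change at the digits printed from compound 2 to compound 3 (within the scatter), with pyridin-4-yl in place of pyridin-3-yl on the aromatic carbon para to a methoxy group. This shows that, at the one oral dose, the read-out does not separate these two placements of the ring nitrogen, which a single measured compound could not show. No evidence is available on what lies behind this result.

Going by these compounds alone, the steps involving compound 1 cannot be read, so the pyridinyl pair remains the only comparison at this position. The compounds shown leave open whether pyridin-2-yl, a plain phenyl or a morpholine at the same carbon would give a comparable read-out, and a single dose says nothing about how the response would vary with dose.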